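Two ureas measured, a third with a straightened chain

The source may report more compounds than this note shows. Statements on the series, on what has been measured and on what is new or still open speak of the compounds shown alone.

Compound 1 `O=C(NCCCOc1cccc(CN2CCCCC2)c1)Nc1cccc(C(F)(F)F)c1`: 813 nM in an assay on isolated protein for inhibition of histamine H2 receptor (Cavia porcellus); on this read-out higher numbers stand for weaker binding and lower numbers for tighter binding
Compound 2 `CC(C)(C)NC(=O)NCCCOc1cccc(CN2CCCCC2)c1`: 2090 nM in this assay

Both compounds share a core in which a urea hangs from a three-carbon chain; only the group on the far urea nitrogen changes. Among the two numbers so far, compound 2 stands highest, and its nearest neighbour is compound 1, separated by the one measured step, a 2.6-fold higher number from compound 1 to compound 2 (0.41 log units; beyond the scatter).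

Compound 3 `CCCCNC(=O)NCCCOc1cccc(CN2CCCCC2)c1` is not yet measured in this assay. It differs from compound 2 by butyl in place of tert-butyl on an amide-type nitrogen. Going by the values given here, no measured step bears directly on this change: the only step in hand swaps an aromatic group for a branched alkyl group, not one alkyl shape for another, so it offers little guidance beyond showing that this position is not indifferent to what sits on it. With no evidence either way, the expectation is that compound 3 lands close to compound 2. The step from compound 2 to compound 3 is expected to be a 1.2-fold lower number from compound 2 to compound 3 (0.06 log units; within the scatter), within the scatter. Compound 3 is therefore estimated at 1800 nM, in a range from 600 nM to 5000 nM.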

Compound 3, dissociation constant: 81.3 nM
Compound 3: middle estimate off by 22-fold (1.35 log units), on the high side; the whole stated range lies above it.
By their numbers in this assay, from the lowest: compound 3; then compound 1; then compound 2.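

Tert-butyl and butyl each hold four carbons and differ only in how those carbons are joined, yet the change on the amide-type nitrogen gives a 26-fold lower number from compound 2 to compound 3 (1.41 log units; beyond the scatter) in this assay. This position therefore distinguishes between two alkyl groups of identical atoms, a sensitivity that the earlier swap of an aromatic group for a branched one could not reveal. Butyl also outdoes the aromatic group, with a 10-fold lower number from compound 1 to compound 3 (1.00 log units; beyond the scatter), so the earlier edge of 3-(trifluoromethyl)phenyl over tert-butyl does not mean that aromatic groups generally beat alkyl groups here. No measurement in hand explains why the straight chain goes with the tighter binding.

These three compounds leave open whether the gain tracks the length of the straight chain or only the absence of branching, a question that a shorter propyl chain, a longer hexyl chain or a lightly branched isobutyl group would help to settle. They also leave open whether the end of the chain tolerates anything other than carbon, such as a terminal amine or a hydroxyl group.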